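Cinnamamide series: trifluorophenyl for trimethoxyphenyl on the chain

This account rests on a few compounds, and the source may have more. Where it says the series, first, only, none or still open, it means among the compounds named here.

Measured so far:
compound 1 `COc1cccc(/C=C/C(=O)Nc2cc(OC)c(OC)c(OC)c2)c1`: 4200 nM
compound 2 `COc1ccc(C(=O)c2cc(OC)c(OC)c(OC)c2)cc1NC(=O)/C=C/c1cc(OC)c(OC)c(OC)c1`: 5200 nM
compound 3 `COc1cc(C(=O)c2cc(OC)c(OC)c(OC)c2)cc(NC(=O)/C=C/c2cc(OC)c(OC)c(OC)c2)c1OC`: 5300 nM

All three were read in a functional assay on COLO 205 cells (Homo sapiens) for cytotoxicity, read by MTT assay, with a stated time of 72 h; a higher number here means a weaker inhibitor, a lower number a stronger inhibitor. Compound 3 has the highest number of the three; the nearest is compound 2, and the two differ by a 1.0-fold higher number from compound 2 to compound 3 (0.01 log units; within the scatter). Compound 1 also sits within the scatter of compound 3, so the three compounds cannot be ordered on these numbers.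

Compound 4 `COc1cc(C(=O)c2cc(OC)c(OC)c(OC)c2)cc(NC(=O)/C=C/c2cc(F)c(F)c(F)c2)c1OC` differs from compound 3 in one place: 3,4,5-trifluorophenyl in place of 3,4,5-trimethoxyphenyl on a double-bonded chain carbon bound to a double-bonded chain carbon. Among the compounds with values here, no measured step changes this aryl group on the chain, so none bears directly on it. Within the data shown here, the only measured step, a methoxy added to the core, left the number essentially unchanged. The values of compound 1 and compound 3 show that a different substitution of the aryl on the chain, together with a different core, gave numbers within the scatter of each other. On this basis a step of at most modest size is expected in this assay, with no firm direction; a slightly higher number is estimated as somewhat more likely than a lower one, since the three measured values cluster near the upper end. Compound 4 is therefore expected to give about 7000 nM, in the range 2000 nM to 25000 nM, corresponding to an expected step of a 1.3-fold higher number from compound 3 to compound 4 (0.12 log units; within the scatter).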

Compound 4, half-maximal inhibitory concentration: 4300 nM
The estimate for compound 4 lay 1.6-fold (0.21 log units) above the measured number; the measured number falls inside the stated range.
By their numbers in this assay, from the lowest: compounds 1, 4, 2 and 3 (each within the scatter of the next).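

In this assay, within the data shown here, this is the first direct change to the aryl group on the chain: 3,4,5-trifluorophenyl in place of 3,4,5-trimethoxyphenyl gives a step within the scatter (a 1.2-fold lower number from compound 3 to compound 4 (0.09 log units; within the scatter)). At this position, the number therefore stays within the scatter when the three methoxy groups give way to three fluorines, even though the entering group has fewer heavy atoms and no hydrogen-bond acceptors. No supporting data are available to explain this result.

On these data alone, whether a differently substituted aryl group at this position, such as 3,4,5-triaminophenyl or 4-carboxyphenyl, would take the number beyond the scatter remains open. Among these compounds, also open is whether any change on the shared core can do so, as the single core step so far stays within the scatter (a 1.0-fold higher number from compound 2 to compound 3 (0.01 log units; within the scatter)).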